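The compounds below may be only part of what the source reports. "The series", "measured", "known", "first", "only" and "open" are said of these compounds alone.

Compound 1 `O=C(Nc1cccc(-n2cc(-c3ccncc3)c(-c3ccc(Cl)c(O)c3)n2)c1)Nc1ccc(Cl)c(Cl)c1` gives 24200 nM.
Compound 2 `COc1cc(-c2nn(-c3cccc(NC(=O)c4ccc(Cl)c(C(F)(F)F)c4)c3)cc2-c2ccncc2)ccc1Cl` gives > 32500 nM.
Compound 3 `COc1cc(-c2nn(-c3cccc(NC(=O)Nc4cccc(C(F)(F)F)c4)c3)cc2-c2ccncc2)ccc1Cl` gives > 50000 nM.

In a functional assay on NCI-H460 cells (Homo sapiens) for inhibition, read by sulforhodamine B assay, with a stated time of 48 h (a higher number here means that more compound is tolerated, a lower number that less compound is tolerated), compound 1 is the only one of the three with a number of its own, 24200 nM. For compound 2 the result is a limit of the assay, > 32500 nM. For compound 3 the result is likewise a limit, > 50000 nM. Compound 2 and compound 3 differ in one place, yet with both ends at limits the step that the two limits leave unreadable from compound 2 to compound 3 gives no readable size.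

Compound 4 `O=C(Nc1cccc(-n2cc(-c3ccncc3)c(-c3ccc(Cl)c(O)c3)n2)c1)Nc1ccc(Cl)c(C(F)(F)F)c1` has not yet been measured. It differs from compound 1 in one place: trifluoromethyl in place of chloro on an aromatic carbon. Among the compounds with values here, no measured step carries this same change. Compound 2 and compound 3, which carry a trifluoromethyl group on a different core, sit at the limit of > 32500 nM in this assay, at which 1 of the 3 values shown sits, and (the limit of > 50000 nM in this assay, at which 1 of the 3 values shown sits), and so say nothing about its size. Within the data shown here, with no step to lean on, the step in this assay is expected to stay within the usual scatter: a 1.0-fold higher number from compound 1 to compound 4 (0.01 log units; within the scatter). Compound 4 is thus estimated at 25000 nM, with a range from 10000 nM to 60000 nM.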

Compound 4, concentration lethal to 50% of the cells: > 32500 nM
Compound 4: no number, only a limit; the forecaster's own chance of this, stated with the estimate: 30%; middle value at least 1.3-fold (0.11 log units) from the limit.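

Compound 1 is the only compound shown with a number of its own, so this change is the first one at this position that can be read at all, if only in one direction. In this assay, trifluoromethyl in place of chloro on this aromatic carbon, ortho to a chloro group and meta to a large group, gives an at least 1.3-fold higher number from compound 1 to compound 4 (0.12 log units; that floor lies within the scatter), which means that the swap did not bring the number down, while the true size of the step stays hidden and only its floor is known. That floor rests on a limit rather than a measured number, and this limit is a common end point in the set: the limit of > 32500 nM in this assay, at which 2 of the 4 values shown sit.

The compounds shown leave open whether the step from chloro to trifluoromethyl truly goes beyond the usual scatter, since that would take a real number for compound 4 rather than a limit. They also leave open how this same place on the ring would respond to a smaller or differently built group, such as a methyl, a nitrile or an amine.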